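Acyl-chain amine change, compound 3 to compound 4

The source may report more compounds than this note shows. Statements on the series, on what has been measured and on what is new or still open speak of the compounds shown alone.

Measured compounds in an assay on L1.2 cells for binding affinity to C-C chemokine receptor type 8 (Homo sapiens); a higher number here means a weaker inhibitor, a lower number a stronger inhibitor:
compound 1, `CCOC(=O)N1CCC(NS(=O)(=O)c2ccc(C(=O)Nc3ccccc3C)c3ccccc23)CC1`: 5.21 nM
compound 2, `Cc1ccccc1C(=O)Nc1ccc(S(=O)(=O)NC2CCN(C(=O)CO)CC2)c2ccccc12`: 5.4 nM
compound 3, `Cc1ccccc1C(=O)Nc1ccc(S(=O)(=O)NC2CCN(C(=O)CCCCN)CC2)c2ccccc12`: 199 nM

Compound 3 stands highest of the three numbers in this assay; its nearest neighbour is compound 2 at 5.4 nM, and compound 1 lies a little further at 5.21 nM. Going by the values given here, the only measured step that touches the acyl chain is a 37-fold higher number from compound 2 to compound 3 (1.57 log units; beyond the scatter), a large loss, and it is the one step that bears on the next compound.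

Compound 4, `CCN(CC)CCCC(=O)N1CCC(NS(=O)(=O)c2ccc(NC(=O)c3ccccc3C)c3ccccc23)CC1`, keeps the shared core and the amine-bearing acyl chain of compound 3 but changes its end: diethylamino in place of aminomethyl on a saturated chain carbon, three bonds along the chain from a carbonyl carbon. Among the compounds with values here, no measured compound carries a tertiary amine on this chain, so there is no direct precedent for the size of the step. What the data show is that the primary-amine chain of compound 3 is costly relative to the hydroxy of compound 2; compound 4 removes the two amine hydrogens and shortens the chain, so some recovery toward compound 2 is plausible, but a full return is not supported by any measured step. A modest improvement, perhaps beyond the scatter, is the working expectation.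

Compound 4 is therefore estimated at 80 nM, with a range of 20 nM to 400 nM. That estimate corresponds to an expected 2.5-fold lower number from compound 3 to compound 4 (0.40 log units; beyond the scatter).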

Compound 4, inhibition constant: 567 nM
Compound 4: middle estimate off by 7.1-fold (0.85 log units), on the low side, and the stated range ends below it.
By their numbers in this assay, from the lowest: compounds 1 and 2 (each within the scatter of the next); then compound 3; then compound 4.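

In this assay, the change from the 4-aminobutyl chain to the 3-(diethylamino)propyl chain gives a 2.8-fold higher number from compound 3 to compound 4 (0.45 log units; beyond the scatter), so loss of the amine hydrogens brings no recovery at this position, and the number moves further from that of the hydroxy compound. Against the hydroxy end, the 2-(diethylamino)ethyl group gives a 110-fold higher number from compound 2 to compound 4 (2.02 log units; beyond the scatter), which shows that the large loss at this position is not confined to the primary amine: both amine-bearing chains shown, in compound 3 and compound 4, stand well on the weak side of compound 2. Nothing measured here accounts for either step.

The step to compound 4 alters chain length and amine substitution together, so the two contributions cannot be separated; a 4-(diethylamino)butyl chain or a 3-aminopropyl chain would divide them. Also open, from the compounds shown here alone, is whether the loss follows the amine nitrogen or the extended chain as such, a question that a plain butyl chain, a methoxy-ended chain or a carboxylic acid at the same chain end would address.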